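This account rests on a few compounds, and the source may have more. Where it says the series, first, only, none or still open, it means among the compounds named here.

Of the compounds shown here, three built on a shared core have so far been tested in a toxicity assay on L02 cells (Homo sapiens) for cytotoxicity, read by MTT assay, with a stated time of 72 h; a higher number here means a weaker inhibitor, a lower number a stronger inhibitor. Compound 1 `O=C1c2c[n+]([O-])c3ccccc3c2C(=O)c2c1c1ccccc1n2Cc1cn(CC(O)CO)nn1` gives 1070 nM. Compound 2 `O=C1c2c[n+]([O-])c3ccccc3c2C(=O)c2c1c1ccccc1n2CCCCN1CCNCC1` gives 1380 nM in this assay, and compound 3 `O=C1c2c[n+]([O-])c3ccccc3c2C(=O)c2c1c1ccccc1n2CCN1CCCC1` gives 930 nM in this assay. Compound 3 stands within the scatter of both of the others, as a 1.2-fold lower number from compound 1 to compound 3 (0.06 log units; within the scatter) and a 1.5-fold lower number from compound 2 to compound 3 (0.17 log units; within the scatter) show, and the remaining pair is likewise close, with a 1.3-fold higher number from compound 1 to compound 2 (0.11 log units; within the scatter).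

Compound 4 `CN1CCN(CCCn2c3c(c4ccccc42)C(=O)c2c[n+]([O-])c4ccccc4c2C3=O)CC1` has not yet been measured in this assay. It differs from compound 3 in one place: (4-methylpiperazin-1-yl)methyl in place of pyrrolidin-1-yl on a saturated chain carbon, two bonds along the chain from an aromatic nitrogen. Among the measured compounds shown here, the steps that bear on this change are the three already seen, each of which reworked the chain on the aromatic nitrogen, either at the saturated chain carbon bound to it or two bonds along the chain, and each of which stayed within the scatter. The chemist therefore expects no step beyond the scatter, a 1.1-fold higher number from compound 3 to compound 4 (0.03 log units; within the scatter). Her estimate for compound 4 in this assay is 1000 nM, with a range from 500 nM to 2000 nM.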

Compound 4, half-maximal inhibitory concentration: 230 nM
Beside the measured number, compound 4's estimate is 4.3-fold (0.64 log units) above it; the whole stated range lies above it.
By their numbers in this assay, from the lowest: compound 4; then compounds 3, 1 and 2 (each within the scatter of the next).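

In this assay, among the compounds shown here, the chain on the aromatic nitrogen turns out to be able to shift the number beyond the scatter, which no step among the earlier compounds did: (4-methylpiperazin-1-yl)methyl in place of pyrrolidin-1-yl, on a saturated chain carbon two bonds along the chain from an aromatic nitrogen, gives a 4.0-fold lower number from compound 3 to compound 4 (0.61 log units; beyond the scatter). Compound 4 also stands clear of the other two, with a 6.0-fold lower number from compound 2 to compound 4 (0.78 log units; beyond the scatter) and a 4.7-fold lower number from compound 1 to compound 4 (0.67 log units; beyond the scatter), so a piperazine ring alone does not account for the shift, since compound 2 also carries one without matching it. The data offer nothing that explains the shift.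

The compounds shown leave open how a 3-(piperazin-1-yl)propyl chain or a 2-(4-methylpiperazin-1-yl)ethyl chain would read, which would separate the methyl group from the chain length. Going by these compounds, a morpholine ring at the end of the propyl chain also remains open.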